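Oleyl ketones against fatty-acid amide hydrolase: heterocycle swap

The source may report more compounds than this note shows. Statements on the series, on what has been measured and on what is new or still open speak of the compounds shown alone.

Measured so far:
compound 1 `CCCCCCCCCCCCCC(=O)C(F)(F)F`: 490 nM
compound 2 `CCCCCCCC/C=C\CCCCCCC(=O)c1nc2cccnc2o1`: 11 nM
compound 3 `CCCCCCCC/C=C\CCCCCCC(=O)c1nc2cccc(C)c2o1`: 13000 nM

In an assay on isolated protein for inhibition of Fatty-acid amide hydrolase 1 (Homo sapiens) (a lower number here means a stronger inhibitor, a higher number a weaker inhibitor), compound 2 gives the lowest number of the three; compound 1 is the nearer of the other two and compound 3 the furthest, both gaps lying beyond the scatter. Compound 4 `CCCCCCCC/C=C\CCCCCCC(=O)c1cccnn1` keeps the oleyl chain and the carbonyl of compound 2 and differs only at the carbonyl carbon: a group of 6 heavy atoms (4 carbon, 2 nitrogen; one six-membered aromatic ring with 2 hetero atoms) in place of a group of 9 heavy atoms (6 carbon, 2 nitrogen, 1 oxygen; one five-membered aromatic ring with 2 hetero atoms, one six-membered aromatic ring with 1 hetero atom), on a carbonyl carbon. Going by the values given here, no step between two measured compounds has the same kind of change, so there is no measured guide for its size. The expectation is a loss of potency, with a 23-fold higher number from compound 2 to compound 4 (1.36 log units; beyond the scatter) estimated as a step upward beyond the scatter. For compound 4 the expected value in this assay is 250 nM, with a range from 60 nM to 1200 nM.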

Compound 4, inhibition constant: 130 nM
Compound 4: the middle estimate sits 1.9-fold (0.28 log units) above what was measured; the measured number falls inside the stated range.
By their numbers in this assay, from the lowest: compound 2; then compound 4; then compound 1; then compound 3.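

Going by these compounds alone, on the carbonyl carbon, with the oleyl chain held constant, pyridazin-3-yl in place of the two-ring group of compound 2 costs potency in this assay, with a 12-fold higher number from compound 2 to compound 4 (1.07 log units; beyond the scatter) as the first measured step at this position. A single six-membered aromatic ring with 2 hetero atoms therefore keeps inhibition in the nanomolar range but does not match the two-ring group. Nothing available accounts for the size of this step.

Still open, going by these compounds, is whether a pyridin-2-yl or pyrimidin-2-yl group on the same carbonyl carbon would give a number nearer that of compound 2. Also open, on these data alone, is what a carboxylic acid on the pyridazin-3-yl ring would do.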